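The compounds below may be only part of what the source reports. "The series", "measured", "known", "first", "only" and "open" are said of these compounds alone.

Measured so far in a functional assay on A-375 cells (Homo sapiens) for antiproliferative activity, read by CCK-8 assay, with a stated time of 72 h, tested at 8 uM; on this read-out higher numbers stand for a stronger effect at the one concentration tested and lower numbers for a weaker effect:
- compound 1 `Nc1ccccc1NC(=O)c1ccc(CSC(=S)N2CCN(Cc3ccccn3)CC2)cc1`: 82.4%
- compound 2 `CN(C(=S)SCc1ccc(C(=O)Nc2ccccc2N)cc1)c1cccnc1`: 87.7%
- compound 3 `Nc1ccccc1NC(=O)c1ccc(CSC(=S)N(Cc2ccccc2)Cc2ccccc2)cc1`: 32.5%

Compound 2 holds the highest of the three numbers in this assay; its gap to compound 1 lies within the usual scatter, while compound 3 stands well beyond the scatter below it. Compound 4 `CN(Cc1ccncc1)C(=S)SCc1ccc(C(=O)Nc2ccccc2N)cc1` has not yet been measured. It differs from compound 2 in one place: (pyridin-4-yl)methyl in place of pyridin-3-yl on an amide-type nitrogen; the other neighbours of that nitrogen are a saturated chain carbon and a thiocarbonyl carbon. Among the measured compounds shown here, no measured pair isolates this change. Compound 1, which also carries a pyridinylmethyl group on its nitrogen, gives 82.4%, so the expectation is a small downward step, possibly within the scatter. For compound 4 the estimated value in this assay is 75% (range 45% to 92%), an expected step of a number 12.7 percentage points lower from compound 2 to compound 4 (beyond the scatter).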

Compound 4, a percentage reported as inhibition, at one concentration (the size of the read-out at that concentration, not a potency): 86.1%
Beside the measured number, compound 4's estimate is 11.1 percentage points below it, within the range that was stated.
By their numbers in this assay, from the lowest: compound 3; then compounds 1, 4 and 2 (each within the scatter of the next).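

In this assay, among the compounds shown here, replacing pyridin-3-yl with (pyridin-4-yl)methyl on the amide-type nitrogen gives a number 1.6 percentage points lower from compound 2 to compound 4 (within the scatter), the first step at this position that isolates one change. At this read-out, the two groups cannot be told apart, so this nitrogen accepts either without a change beyond the scatter. No data at hand explain this result. The step alone cannot separate the added carbon from the different ring attachment, and pyridin-4-yl and (pyridin-3-yl)methyl would be needed to do so. As far as these compounds go, how a longer chain ending in a dimethylamino group would read on this nitrogen also remains open.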